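From 2,3-Dimethylbenzyl to 3,4-Dimethylbenzyl

The compounds below may be only part of what the source reports. "The series", "measured", "known", "first", "only" and "open" are said of these compounds alone.

In a functional assay on Jurkat cells (Homo sapiens) (a higher number here means a weaker inhibitor, a lower number a stronger inhibitor), compound 1 `C[C@H](NC(=O)C(=O)NCc1ccc(Cl)cc1)C(=O)N[C@@H](CC(=O)O)C(=O)COc1c(F)c(F)cc(F)c1F` gives 8.4 nM, compound 2 `C[C@H](NC(=O)C(=O)Nc1cccnc1N(C)C)C(=O)N[C@@H](CC(=O)O)C(=O)COc1c(F)c(F)cc(F)c1F` gives 27 nM and compound 3 `Cc1cccc(CNC(=O)C(=O)N[C@@H](C)C(=O)N[C@@H](CC(=O)O)C(=O)COc2c(F)c(F)cc(F)c2F)c1C` gives 102 nM, the highest number of the three and so the weakest inhibitor here. Compound 4 `Cc1ccc(CNC(=O)C(=O)N[C@@H](C)C(=O)N[C@@H](CC(=O)O)C(=O)COc2c(F)c(F)cc(F)c2F)cc1C` differs from it in one group: 3,4-dimethylphenyl in place of 2,3-dimethylphenyl on a saturated chain carbon bound to an amide-type nitrogen. The most relevant evidence is the large 12-fold higher number from compound 1 to compound 3 (1.08 log units; beyond the scatter), where 2,3-dimethylphenyl replaces 4-chlorophenyl. The modest 3.8-fold higher number from compound 2 to compound 3 (0.58 log units; beyond the scatter) and a 3.2-fold higher number from compound 1 to compound 2 (0.51 log units; beyond the scatter) bear less, since both involve 2-(dimethylamino)pyridin-3-yl. Among the compounds with values here, by name, 3,4-dimethylphenyl looks closer to 4-chlorophenyl, but no measured compound tests this, so the expectation is loose. The expected change is a 3.4-fold lower number from compound 3 to compound 4 (0.53 log units; beyond the scatter), towards stronger inhibition. For compound 4 the estimate is 30 nM, with an expected range of 9 nM to 100 nM.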

Compound 4, half-maximal inhibitory concentration: > 10000 nM
Compound 4: a limit, no number; the forecaster's own chance of this, stated with the estimate: 2%; middle value at least 330-fold (2.52 log units) away from the limit.
By their numbers in this assay, from the lowest: compound 1; then compound 2; then compound 3. At a limit, above all of these: compound 4.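

Compound 4 gives only a limit, not a number: the limit of > 10000 nM in this assay, at which 1 of the 4 values shown sits. Exchanging 2,3-dimethylphenyl for 3,4-dimethylphenyl, the same atoms joined differently, gives an at least 98-fold higher number from compound 3 to compound 4 (1.99 log units; beyond the scatter), so rearranging the two methyl groups alone can nearly abolish activity in this assay. Within the data shown here, the other gaps, an at least 370-fold higher number from compound 2 to compound 4 (2.56 log units; beyond the scatter) and an at least 1100-fold higher number from compound 1 to compound 4 (3.07 log units; beyond the scatter), also exceed every step among the earlier compounds.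

Still open, going by these compounds, is whether 3-methylbenzyl or 4-methylbenzyl alone would behave like 3,4-dimethylbenzyl, and whether 3,4-dichlorobenzyl would track 4-chlorobenzyl. These values also cannot explain why this change matters so much.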